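Lengthening the amine-bearing chain of a bornyl ester

The source may hold more compounds than are shown below. What is called first, only, known or untested is meant among the compounds shown, and "the series" means these compounds.

Three esters of a shared core have been measured in an ADME assay on HEK-293T cells (Homo sapiens) for cytotoxicity, read by MTT assay, with a stated time of 48 h; on this read-out lower numbers stand for higher toxicity in this test and higher numbers for lower toxicity in this test. Compound 1 `CCN1CCN(CCCC(=O)O[C@@H]2C[C@@H]3CC[C@@]2(C)C3(C)C)CC1` gives 131000 nM, and compound 2 `CC1(C)[C@H]2CC[C@]1(C)[C@H](OC(=O)CCCN1CCCCCC1)C2` gives 62200 nM. Among the compounds with values here, the step of a 2.1-fold lower number from compound 1 to compound 2 (0.32 log units; beyond the scatter) is the only measured pair differing in one place. Compound 3 `CN(C)CC(=O)O[C@@H]1C[C@@H]2CC[C@@]1(C)C2(C)C` gives 389000 nM, the highest of the three numbers, and its gaps to compound 1 and compound 2 both lie beyond the scatter. Compound 4 `CN(C)CCCC(=O)O[C@@H]1C[C@@H]2CC[C@@]1(C)C2(C)C` is the next compound to be measured. It differs from compound 3 by 2-(dimethylamino)ethyl in place of dimethylamino on a saturated chain carbon bound to a carbonyl carbon. Within the data shown here, no measured step covers this exact change: the step from compound 1 to compound 2 alters the amine ring rather than the chain length. What the numbers do show is that compound 1 and compound 2, which carry the longer chain, sit below compound 3. On that basis compound 4 is expected to fall between these values, with a step of a 2.2-fold lower number from compound 3 to compound 4 (0.33 log units; beyond the scatter) estimated as a modest lowering. The estimated value for compound 4 in this assay is 180000 nM, with a range from 70000 nM to 400000 nM.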

Compound 4, half-maximal cytotoxic concentration: 101000 nM
For compound 4 the middle estimate is 1.8-fold (0.25 log units) above the measured one; low and high end bracket the measured number.
By their numbers in this assay, from the lowest: compounds 2, 4 and 1 (each within the scatter of the next, the first and the last beyond it); then compound 3.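

Read with the amine held as dimethylamino, the longer chain now has its own direct measure in this assay: 2-(dimethylamino)ethyl in place of dimethylamino lowers the number beyond the scatter (a 3.9-fold lower number from compound 3 to compound 4 (0.59 log units; beyond the scatter)). Once the chain is long, dimethylamino cannot be told apart from azepan-1-yl (a 1.6-fold higher number from compound 2 to compound 4 (0.21 log units; within the scatter)) or from 4-ethylpiperazin-1-yl (a 1.3-fold lower number from compound 1 to compound 4 (0.11 log units; within the scatter)), as both steps lie within the scatter. The end amine therefore matters little in these two comparisons, although the step between the two ring amines goes against this and lies just beyond the scatter (a 2.1-fold lower number from compound 1 to compound 2 (0.32 log units; beyond the scatter)).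

No measurement here explains why the number falls with this change. Also open, as far as these compounds go, are whether a still longer chain would lower the number further, and whether azepan-1-yl on the short chain of compound 3 would give a similar number.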